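The source may report more compounds than this note shows. Statements on the series, on what has been measured and on what is new or still open speak of the compounds shown alone.

Three ureas that share one core have been measured in an ADME assay on the whole organism with Oryza sativa as the target, tested at 10 uM; on this read-out lower numbers stand for a stronger effect and higher numbers for a weaker effect at the one concentration tested. Compound 1 `C[C@@H](NC(=O)Nc1ccccc1C(C)(C)C)c1ccccc1` gives 17% in this assay. Compound 2 `C[C@@H](NC(=O)Nc1ccccc1Cl)c1ccccc1` gives 93%, and compound 3 `C[C@@H](NC(=O)Nc1ccc(Cl)cc1Cl)c1ccccc1` gives 100%. Among these three numbers, compound 2 stands second highest: its nearest neighbour is compound 3, whose value lies within the usual scatter of it, while compound 1 lies far below it, beyond the scatter. Going by the values given here, the single large step in the set is a number 76 percentage points higher from compound 1 to compound 2 (beyond the scatter), which came with a chloro in place of tert-butyl on an aromatic carbon. The other step, a number 7 percentage points higher from compound 2 to compound 3 (within the scatter), came with a chloro in place of hydrogen on an aromatic carbon and stayed inside the scatter.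

Compound 4 `C[C@@H](NC(=O)Nc1cc(Cl)ccc1Cl)c1ccccc1` is not yet measured. It differs from compound 2 as follows: chloro in place of hydrogen on an aromatic carbon. Among the compounds with values here, the step that bears on this change is the one from compound 2 to compound 3, since it is also a chloro in place of hydrogen on an aromatic carbon, and it was small. The expectation is therefore a step of a number 2 percentage points higher from compound 2 to compound 4 (within the scatter) from compound 2 to compound 4, that is, nothing beyond the scatter. Compound 4 is estimated at 95%, with a range from 80% to 100%.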

Compound 4, a percentage reported as activity, at one concentration (the size of the read-out at that concentration, not a potency): 101%
Estimate against measurement, compound 4: 6 percentage points below; the measured number lies above the stated range.
By their numbers in this assay, from the lowest: compound 1; then compounds 2, 3 and 4 (each within the scatter of the next).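

In this assay, putting a chloro on this aromatic carbon, meta to a large group and para to a chloro group, gives a number 8 percentage points higher from compound 2 to compound 4 (within the scatter), so this swap of hydrogen for chloro does not move the number beyond the usual scatter. Until now the same swap had been seen at only one other aromatic carbon, in compound 3, so the result shows that the outcome is not confined to that one place, with compound 3 at 100% and compound 4 at 101% lying within the scatter of each other. The data offer no measurement that would explain why this added chloro leaves the read-out where it is.

Going by these compounds, the only large shift in the set remains a number 76 percentage points higher from compound 1 to compound 2 (beyond the scatter), and whether a tert-butyl on this same carbon would bring the number down as it does in compound 1 remains open. Also open, on these data alone, is whether a group of a different kind here, such as an amine, a methoxy group or a carboxylic acid, would shift the number or leave it within the scatter of compound 2.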